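A few compounds are considered here, and "the series" means these few. Any claim that something is new, unique, unknown or untested is made for them only; others in the source may bear on it.

Compound 1, `COc1ccc(C(=O)Nc2ccccc2Cl)cc1OC1CCCC1`: 190 nM
Compound 2, `COc1ccc(C(=O)Nc2ccccc2C)cc1OC1CCCC1`: 300 nM
Compound 3, `COc1ccc(C(=O)Nc2cccnc2)cc1OC1CCCC1`: 550 nM

In an assay on isolated protein for inhibition of phosphodiesterase 4A (Sus scrofa) (a lower number here means a stronger inhibitor, a higher number a weaker inhibitor), compound 3 stands highest of the three. The step of a 2.9-fold higher number from compound 1 to compound 3 (0.46 log units; beyond the scatter) is beyond the scatter, whereas a 1.8-fold higher number from compound 2 to compound 3 (0.26 log units; within the scatter) is within it, so compound 3 and compound 2 cannot be ordered. Compound 4 is `COc1ccc(C(=O)Nc2nccs2)cc1OC1CCCC1`; it differs from compound 3 by 1,3-thiazol-2-yl in place of pyridin-3-yl on an amide-type nitrogen. Going by the values given here, the only measured steps that touch this position are the two exchanges of the aryl group on the amide nitrogen, a 2.9-fold higher number from compound 1 to compound 3 (0.46 log units; beyond the scatter) and a 1.8-fold higher number from compound 2 to compound 3 (0.26 log units; within the scatter), both raising the number. Among the compounds with values here, no measured pair exchanges one heteroaryl for another, so the step of a 1.5-fold higher number from compound 3 to compound 4 (0.16 log units; within the scatter) is expected to be small, at most a modest rise. Compound 4 is therefore estimated at 800 nM, between 350 nM and 2000 nM.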

Compound 4, half-maximal inhibitory concentration: 6500 nM
The estimate for compound 4 lay 8.1-fold (0.91 log units) below the measured number, and the stated range ends below it.
By their numbers in this assay, from the lowest: compounds 1, 2 and 3 (each within the scatter of the next, the first and the last beyond it); then compound 4.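

In this assay, going by these compounds alone, the group on the amide-type nitrogen proved far less forgiving than the earlier compounds suggested: exchanging pyridin-3-yl for 1,3-thiazol-2-yl gives a large step (a 12-fold higher number from compound 3 to compound 4 (1.07 log units; beyond the scatter)). The steps from the two substituted phenyl compounds are larger still (a 22-fold higher number from compound 2 to compound 4 (1.34 log units; beyond the scatter); a 34-fold higher number from compound 1 to compound 4 (1.53 log units; beyond the scatter)), which sets compound 4 apart from all three others. No evidence at hand accounts for this loss. Going by these compounds, it remains open whether a pyridin-2-yl or 1,3-oxazol-2-yl group would behave like 1,3-thiazol-2-yl, and whether a methyl or chloro group on the 1,3-thiazol-2-yl ring would lower the number.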